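Acetyl in Place of Ethylsulfonyl on a Ring Nitrogen

The compounds below may be only part of what the source reports. "The series", "measured", "known", "first", "only" and "open" are said of these compounds alone.

Compound 1 `CC(=O)N1CC[C@@H](Oc2cncc(N3C(=O)c4ccc(Cl)cc4C3(C)C)c2)C1`: 11 nM
Compound 2 `CC(=O)N1CCC(c2cncc(N3C(=O)c4ccc(Cl)cc4C3(C)C)c2)CC1`: 5 nM
Compound 3 `CCS(=O)(=O)N1CC2(CN(c3cncc(N4C(=O)c5ccc(Cl)cc5C4(C)C)c3)C2)C1`: 16 nM

In an assay on cells for inhibition of cytochrome P450 11B2, mitochondrial (Homo sapiens), read by HTRF (on this read-out lower numbers stand for stronger inhibition and higher numbers for weaker inhibition), compound 3 gives the highest of the three numbers; compound 1 sits within the scatter of it, while compound 2 lies beyond it. Compound 4 `CC(=O)N1CC2(C1)CN(c1cncc(N3C(=O)c4ccc(Cl)cc4C3(C)C)c1)C2` differs from compound 3 by acetyl in place of ethylsulfonyl on an amine nitrogen in a ring. No measured step swaps the cap on a ring nitrogen alone; the only step shown, a 2.2-fold lower number from compound 1 to compound 2 (0.34 log units; beyond the scatter), alters the ring rather than the acetyl. Both compounds 1 and 2 carry acetyl on a ring nitrogen and give low numbers, so a shift toward them is plausible but unsecured. Compound 4 is therefore expected to show a 1.3-fold lower number from compound 3 to compound 4 (0.12 log units; within the scatter), a step that need not exceed the scatter. Compound 4 is estimated at 12 nM, within 5 nM to 30 nM.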

Compound 4, half-maximal inhibitory concentration: 23 nM
Estimate against measurement, compound 4: 1.9-fold (0.28 log units) below, and the stated range covers the measured number.
By their numbers in this assay, from the lowest: compound 2; then compounds 1, 3 and 4 (each within the scatter of the next, the first and the last beyond it).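

In this assay, acetyl in place of ethylsulfonyl on the amine nitrogen of the four-membered non-aromatic ring gives a 1.4-fold higher number from compound 3 to compound 4 (0.16 log units; within the scatter). Within the data shown here, this is the first step to change only the cap on a ring nitrogen, and it shows that on this ring system the two caps cannot be told apart in this assay. Nothing measured here offers an explanation for this result.

The compounds shown leave open how a methylsulfonyl, a urea or the free ring amine would read on this nitrogen. They also leave open whether ethylsulfonyl and acetyl would again read alike on the six-membered non-aromatic ring of compound 2.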